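Aryl Exchange on the Ring Nitrogen of an Inactive Scaffold

A few compounds are considered here, and "the series" means these few. Any claim that something is new, unique, unknown or untested is made for them only; others in the source may bear on it.

Compound 1 `N#CC1=C(N)Oc2c(c3nc4ccccc4nc3c3ccccc23)C12C(=O)N(Cc1cnnn1-c1cccc(Br)c1)c1ccccc12` and compound 2 `COc1ccccc1-n1nncc1CN1C(=O)C2(C(C#N)=C(N)Oc3c(N)cc4nc5ccccc5nc4c32)c2ccccc21` share a core that carries a five-membered aromatic ring with 3 nitrogen on one arm. In a functional assay on HCT-116 cells (Homo sapiens) for antiproliferative activity, read by MTT assay, with a stated time of 48 h (on this read-out lower numbers stand for stronger inhibition and higher numbers for weaker inhibition), compound 1 reaches only a limit, > 50000 nM. Compound 2 likewise reaches only a limit in this assay, > 50000 nM. For the measured compounds named here, compound 2 therefore stands at the edge of what was measured: both values shown sit at the same limit (the limit of > 50000 nM in this assay, at which 2 of the 2 values shown sit), and no step between measured compounds exists to describe.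

Compound 3 `Cc1ccc(-n2nncc2CN2C(=O)C3(C(C#N)=C(N)Oc4c(N)cc5nc6ccccc6nc5c43)c3ccccc32)cc1Cl` differs from compound 2 by 3-chloro-4-methylphenyl in place of 2-methoxyphenyl on an aromatic nitrogen. Since only limits are known for compound 2 and compound 1, there is no measured direction to lean on. In this assay compound 3 is expected to remain at or near the limit, and the step that the limit leaves unreadable from compound 2 to compound 3 is estimated to be none beyond the scatter. Compound 3 is thus estimated at 60000 nM, between 20000 nM and 200000 nM, most likely to be reported again as a limit rather than a number.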

Compound 3, half-maximal inhibitory concentration: > 50000 nM
Compound 3: no number, only a limit; the forecaster's own chance of this, stated with the estimate: 85%; the middle value lies beyond the limit too.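

No step can be read between compound 2 and compound 3, since each gives only a limit and not a number: the limit of > 50000 nM in this assay, at which 3 of the 3 values shown sit.

The compounds shown leave open how the three compare with one another, and whether any change on the aromatic nitrogen would give a measurable value in this assay.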